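This account rests on a few compounds, and the source may have more. Where it says the series, first, only, none or still open, it means among the compounds named here.

Of the compounds shown here, two of this small set have been tested in a functional assay on U-373MG ATCC cells (Homo sapiens) for inhibition, read by colorimetric assay and MTT assay, with a stated time of 72 h; on this read-out higher numbers stand for weaker inhibition and lower numbers for stronger inhibition. Compound 1, `COc1ccc(C(=O)NNC(=S)Nc2csc(-c3ccc(C)cc3)c2)cc1OC`, gives 47000 nM in this assay. Compound 2, `COc1ccc(-c2cc(Nc3nnc(-c4ccc(C)cc4)s3)cs2)cc1`, is recorded only as a limit of this assay: its value stands at > 100000 nM. The limit is the line at the limit of > 100000 nM in this assay, at which 1 of the 2 values shown sits, so compound 2 has no measured number, only a floor for its half-maximal inhibitory concentration. Within the data shown here, no step between measured compounds connects them.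

Compound 3, `Cc1ccc(-c2nnc(Nc3csc(-c4ccccc4)c3)s2)cc1`, has not yet been measured. It differs from compound 2 in one place: hydrogen in place of methoxy on an aromatic carbon. Since compound 2 already sits at the limit, a step from compound 2 to compound 3 of a step that the limit leaves unreadable from compound 2 to compound 3 is expected, that is nothing beyond the scatter. Compound 3 is therefore expected to give about 110000 nM in this assay, with a range from 35000 nM to 350000 nM, and it may well again be reported only as a limit.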

Compound 3, half-maximal inhibitory concentration: > 100000 nM
Compound 3: a limit, no number (the forecaster's own chance of this, stated with the estimate: 70%); the middle value does not contradict the limit.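

In this assay compound 2 and compound 3 both stand only as limits, and no step between them can be read: the limit of > 100000 nM in this assay, at which 2 of the 3 values shown sit.

The compounds shown leave open whether going from 4-methoxyphenyl to phenyl changes inhibition at all in this assay.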